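Enlarging the Acyl Group: Compound 3 to Compound 4

This account rests on a few compounds, and the source may have more. Where it says the series, first, only, none or still open, it means among the compounds named here.

Of the compounds shown here, three of a shared core have been tested in an assay on HEK293 cells for negative allosteric modulation of metabotropic glutamate receptor 5 (Homo sapiens), read by FLIPR, with a stated time of 1 h; on this read-out lower numbers stand for stronger inhibition and higher numbers for weaker inhibition. Compound 1 `O=C1NCCc2nc(C#Cc3ccccc3)sc21` reaches only the limit of > 10000 nM in this assay. Compound 2 `O=C1c2sc(C#Cc3ccccc3)nc2CN1C1CC1` gives 23 nM in this assay. Compound 3 `CC(=O)N1CCc2nc(C#Cc3ccccc3)sc2C1` gives 90 nM in this assay, the higher of the two numbers, and its gap to compound 2 lies beyond the scatter. Compound 4 `O=C(C1CCCCC1)N1CCc2nc(C#Cc3ccccc3)sc2C1` differs from compound 3 in one place: cyclohexyl in place of methyl on a carbonyl carbon. No comparable change has been measured in this set, so the size of the step is open. The step from compound 3 to compound 4 is expected to be small, at most slightly beyond the scatter, and more likely toward a higher number than a lower one. Compound 4 is therefore estimated at 150 nM in this assay, with a range from 40 nM to 600 nM. This means an expected step of a 1.7-fold higher number from compound 3 to compound 4 (0.22 log units; within the scatter).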

Compound 4, half-maximal inhibitory concentration: > 10000 nM
Compound 4 gave a limit, no number (the forecaster's own chance of this, stated with the estimate: 5%); middle value at least 66-fold (1.82 log units) away from the limit.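

In this assay, the group on this carbonyl carbon matters greatly: cyclohexyl in place of methyl brings an at least 110-fold higher number from compound 3 to compound 4 (2.04 log units; beyond the scatter) and thus a far larger change than a modest enlargement of the acyl group might suggest. The reading for compound 4 is a limit of the assay and not a number, and it is not the only one: the limit of > 10000 nM in this assay, at which 2 of the 4 values shown sit. The compounds shown leave open where between methyl and cyclohexyl the loss sets in, as ethyl, isopropyl or cyclopropyl on the same carbonyl carbon would show. They also leave open whether phenyl or a cyclohexyl bearing an amine behaves the same way.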